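This account rests on a few compounds, and the source may have more. Where it says the series, first, only, none or still open, it means among the compounds named here.

Three compounds share one core and differ only in the group attached to the carbonyl carbon of the amide. Among the measured compounds shown here, compound 1 `Cc1nc(NC(=O)C(C)(C)CC(F)(F)F)sc1-c1ccc(N)nc1` is the first of them. In a physicochemical assay for solubility, at pH 2 (a higher number here means a more soluble compound, a lower number a less soluble compound), compound 1 gives > 1000 ug/mL, which is a limit of the assay rather than a number. Compound 2 `Cc1nc(NC(=O)CN(Cc2ccccc2)C(=O)c2ccncc2)sc1-c1ccc(N)nc1` carries a different side chain on that carbonyl carbon. In this assay compound 2 gives > 987 ug/mL, again a limit. Compound 3 `Cc1nc(NC(=O)C2(C)CCCCC2)sc1-c1ccc(N)nc1` carries a 1-methylcyclohexyl group there. In this assay compound 3 gives > 1000 ug/mL, also a limit. The step that the two limits leave unreadable from compound 1 to compound 3 cannot be read because both of its ends sit at the limit of > 1000 ug/mL in this assay, at which 2 of the 3 values shown sit, and compound 3 therefore stands at the top of what this assay can report, as do the other two. Compound 4 `CO[C@H]1CC[C@@H](C(=O)Nc2nc(C)c(-c3ccc(N)nc3)s2)CC1` is not yet measured. It differs from compound 3 in one place: 4-methoxycyclohexyl in place of 1-methylcyclohexyl on a carbonyl carbon. For the measured compounds named here, no measured step bears on this change, since every measured value is hidden behind a limit. The expectation for compound 4 in this assay is that it remains near that limit, at 1000 ug/mL, with a range from 400 ug/mL to 1000 ug/mL. The step of a number no higher from compound 3 to compound 4 (the limit leaves the size open) is expected to stay within the scatter.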

Compound 4, solubility: > 1000 ug/mL
Compound 4: a limit, no number; the forecaster's own chance of this, stated with the estimate: 70%; the middle value lies on the limit itself.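

In this assay neither the step from compound 3 to compound 4 nor the step from compound 1 to compound 4 can be read, because all three compounds sit at the same limit: the limit of > 1000 ug/mL in this assay, at which 3 of the 4 values shown sit.

The compounds shown leave open what number each of them would give, and so how 4-methoxycyclohexyl compares with 1-methylcyclohexyl on the carbonyl carbon.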